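Pyrazole ureas on HT-29 cells: one remaining analogue

The source may report more compounds than this note shows. Statements on the series, on what has been measured and on what is new or still open speak of the compounds shown alone.

Measured compounds:
compound 1 `O=C(Nc1cccc(-n2cc(-c3ccncc3)c(-c3ccc(Cl)c(O)c3)n2)c1)Nc1cccc(C(F)(F)F)c1`: 9820 nM
compound 2 `COc1cc(-c2nn(-c3cccc(NC(=O)Nc4ccc(Cl)c(Cl)c4)c3)cc2-c2ccncc2)ccc1Cl`: 1240 nM
compound 3 `O=C(Nc1cccc(-n2cc(-c3ccncc3)c(-c3ccc(Cl)c(O)c3)n2)c1)Nc1ccc(Cl)c(Cl)c1`: 4890 nM

All three share a pyrazole urea core and were run in a functional assay on HT-29 cells (Homo sapiens) for inhibition, read by sulforhodamine B assay, with a stated time of 48 h; a higher number here means a weaker inhibitor of growth, a lower number a stronger inhibitor of growth. Compound 2 carries the lowest number of the three; compound 3 stands nearest to it, and compound 1 furthest.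

Two changes are seen among the measured compounds. The first is methyl in place of hydrogen on an oxygen on an aromatic ring; the step it made is a 3.9-fold higher number from compound 2 to compound 3 (0.60 log units; beyond the scatter). The second is 3-(trifluoromethyl)phenyl in place of 3,4-dichlorophenyl on an amide-type nitrogen; its step is a 2.0-fold higher number from compound 3 to compound 1 (0.30 log units; within the scatter).

The unmeasured compound 4 `COc1cc(-c2nn(-c3cccc(NC(=O)Nc4cccc(C(F)(F)F)c4)c3)cc2-c2ccncc2)ccc1Cl` relates to compound 2 as compound 1 relates to compound 3. The difference is 3-(trifluoromethyl)phenyl in place of 3,4-dichlorophenyl on an amide-type nitrogen, the same change as between compound 3 and compound 1; the two place descriptions agree word for word, and the difference between the cores of compound 2 and compound 3 is the methoxy-for-hydroxy change already given. With one prior instance of the change, the expectation rests on that single step. The step from compound 2 to compound 4 in this assay is estimated as a 2.0-fold higher number from compound 2 to compound 4 (0.30 log units; within the scatter), on the ground that the same change gave a 2.0-fold higher number from compound 3 to compound 1 (0.30 log units; within the scatter). Compound 4 is therefore expected near 2500 nM, with a range from 1000 nM to 6500 nM. Going by the values given here, the range is wider than the single precedent; one instance cannot fix how the step transfers to the methoxy core.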

Compound 4, concentration for 50% growth inhibition: 748 nM
For compound 4 the middle estimate is 3.3-fold (0.52 log units) above the measured one; the measured number lies below the stated range.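

In this assay, 3-(trifluoromethyl)phenyl in place of 3,4-dichlorophenyl on an amide-type nitrogen gives a 1.7-fold lower number from compound 2 to compound 4 (0.22 log units; within the scatter), so the step seen on the core of compound 3 does not carry over unchanged to the core of compound 2, even though each step on its own stays within the scatter: the same change on two cores in this assay, a 2.0-fold higher number (0.30 log units; within the scatter) from compound 3 to compound 1 and a 1.7-fold lower number (0.22 log units; within the scatter) from compound 2 to compound 4, 3.3-fold (0.52 log units) apart, beyond the scatter of two such steps. Read the other way round the same four compounds, methyl in place of hydrogen on an oxygen on an aromatic ring gives a 13-fold lower number from compound 1 to compound 4 (1.12 log units; beyond the scatter), and the size of this step depends on the group on the amide-type nitrogen: the same change on two cores in this assay, a 3.9-fold higher number (0.60 log units; beyond the scatter) from compound 2 to compound 3 and a 13-fold higher number (1.12 log units; beyond the scatter) from compound 4 to compound 1, 3.3-fold (0.52 log units) apart, beyond the scatter of two such steps. These two gaps come from one set of four compounds, so they count as a single observation that the two changes do not add up independently, and they show neither why this happens nor how either change would behave on a further core.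

Still open, as far as these compounds go, is whether the same dependence holds for an ethyl group or a longer chain on that oxygen, or for an amine in place of the methoxy group. Also open, from the compounds shown here alone, is how other groups on the amide-type nitrogen, such as a pyridine ring or a phenyl ring bearing a carboxylic acid, would fit this picture.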